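The source may hold more compounds than are shown below. What is called first, only, known or untested is meant among the compounds shown, and "the series" means these compounds.

The series is built on one shared saturated bicyclic core that carries a carbonyl substituent. Compound 1 `COC(=O)[C@H]1C[C@H]2CNC[C@H]2C1` bears a methyl ester on that core, and in an assay on SHEP1 cells for agonist activity at Neuronal acetylcholine receptor; alpha4/beta2 (Homo sapiens), read by FLIPR and calcium flux (on this read-out higher numbers stand for larger maximal responses and lower numbers for smaller maximal responses), compound 1 gives 130%. Compound 2 `O=C(C1CC1)[C@H]1C[C@@H]2CNC[C@@H](C2)C1` carries a cyclopropyl ketone instead, and in this assay compound 2 gives 22%. Compound 3 `O=C(c1ccco1)[C@H]1C[C@@H]2CNC[C@@H](C2)C1` carries a furan-2-yl ketone; in this assay the entry for compound 3 reads "not determined" (no result reported), so no single number for compound 3 is available and its standing among the measured compounds cannot be fixed. The step from compound 3 to compound 4 `CNC(=O)[C@H]1C[C@@H]2CNC[C@@H](C2)C1` consists of the change (methylamino in place of furan-2-yl on a carbonyl carbon). With no number for compound 3, neither the size nor the direction of this step in this assay can be anchored to a measured starting point; it may be no larger than the scatter or may reach the spread that separates compound 1 from compound 2. The expectation for compound 4 must therefore rest on the values of compound 1 and compound 2 alone, which span a wide range. On that basis compound 4 is estimated to give 60% in this assay, with an expected range from 15% to 130%.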

Compound 4, largest response reached (Emax), in percent of the reference or control that the assay uses: 65%
For compound 4 the middle estimate is 5 percentage points below the measured one, and the stated range covers the measured number.
By their numbers in this assay, from the lowest: compound 2; then compound 4; then compound 1.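

In this assay, going by these compounds alone, methylamino in place of cyclopropyl on a carbonyl carbon gives a number 43 percentage points higher from compound 2 to compound 4 (beyond the scatter), the first comparison in which only this group changes on the same core. It shows that the maximal response is sensitive to the group at this position and that, of these two groups, methylamino gives the larger response. The step from compound 3 cannot be read, and nothing measured here explains the rise seen with methylamino.

The compounds shown leave open where furan-2-yl stands relative to cyclopropyl and methylamino at this carbonyl carbon. They also leave open whether the amide hydrogen matters, which a dimethylamino group would address, and how an unsubstituted amino group or a longer chain such as ethylamino would read here.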